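This account rests on a few compounds, and the source may have more. Where it says the series, first, only, none or still open, it means among the compounds named here.

Measured in a functional assay on HCC827 cells (Homo sapiens) for antiproliferative activity, read by MTT assay, with a stated time of 72 h; on this read-out higher numbers stand for weaker inhibition and lower numbers for stronger inhibition:
- compound 1 `CN1CCN(c2ccc(Nc3ncc4nc(Nc5ccc(F)cc5)n([C@H]5CCCN(C(=O)CO)C5)c4n3)cc2)CC1`: 1.8 nM
- compound 2 `CN1CCN(c2ccc(Nc3ncc4nc(Nc5ccccc5)n([C@H]5CCN(S(C)(=O)=O)C5)c4n3)cc2)CC1`: 17 nM
- compound 3 `CC(=O)N1CC[C@H](n2c(Nc3ccccc3)nc3cnc(Nc4ccc(N5CCN(C)CC5)cc4)nc32)C1`: 260 nM

Compound 1 holds the lowest number of the three, and both other compounds lie beyond the scatter from it, so it is the strongest inhibitor of this small set. The step followed here leads from it to compound 4 `CN1CCN(c2ccc(Nc3ncc4nc(Nc5ccc(F)cc5)n(CCNS(=O)(=O)C5CC5)c4n3)cc2)CC1`, and the change is 2-((cyclopropylsulfonyl)amino)ethyl in place of 1-((hydroxymethyl)carbonyl)piperidin-3-yl on an aromatic nitrogen. The piperidine-bearing group gives way to an open chain that ends in a three-membered ring of carbon only.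

For the measured compounds named here, only one measured step bears on this, and only in part: a 15-fold higher number from compound 2 to compound 3 (1.18 log units; beyond the scatter), a large step for acetyl in place of methylsulfonyl on an amine nitrogen in a ring. It shows that a small change in this part of the molecule can move the number widely. Compound 4 keeps a sulfonyl group, as does compound 2 at 17 nM. Going by the values given here, no measured step replaces a ring-bearing group with an open chain, so the size of the change remains uncertain. A higher number than that of compound 1 is expected, beyond the scatter, and the estimated step runs an 8.3-fold higher number from compound 1 to compound 4 (0.92 log units; beyond the scatter). For compound 4 the expected value is 15 nM, with an estimated range from 3 nM to 80 nM.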

Compound 4, half-maximal inhibitory concentration: 50 nM
Estimate against measurement, compound 4: 3.3-fold (0.52 log units) below; measured number inside the range.
By their numbers in this assay, from the lowest: compound 1; then compound 2; then compound 4; then compound 3.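

In this assay, putting 2-((cyclopropylsulfonyl)amino)ethyl in place of 1-((hydroxymethyl)carbonyl)piperidin-3-yl on the aromatic nitrogen gives a 28-fold higher number from compound 1 to compound 4 (1.44 log units; beyond the scatter), so replacing the whole ring-bearing group with an open chain, with the (4-fluorophenyl)amino group kept, carries a large penalty at this position. The earlier step showed only an exchange on a ring amine nitrogen with the ring kept, whereas this one shows that the number also moves widely when the six-membered ring and the defined stereocentre leave, even though the two groups match in their counted hydrogen-bond donors and acceptors and in net charge. Nothing measured here gives a cause for this step.

The change swaps the ring, the chain and the sulfonyl for carbonyl exchange all at once, so the compounds shown do not tell which of these parts accounts for the step. As far as these compounds go, a piperidin-3-yl group bearing cyclopropylsulfonyl on its nitrogen, or a longer chain ending in the same cyclopropylsulfonyl amine, would separate these parts, and how either reads in this assay remains open.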